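This account rests on a few compounds, and the source may have more. Where it says the series, first, only, none or still open, it means among the compounds named here.

Measured so far, in an ADME assay on HEL cells (Homo sapiens) for cytotoxicity; a higher number here means that more compound is tolerated, a lower number that less compound is tolerated:

- compound 1, `O=C(COc1cccc2ccccc12)N/N=C/c1ccc(Cl)cc1`, gives 100 ug/mL.
- compound 2, `COc1ccc(OC)c(/C=N/NC(=O)COc2cccc3ccccc23)c1`, gives >= 20 ug/mL; this is a limit of the assay, not a number.
- compound 3, `C/C(=N\NC(=O)COc1cccc2ccccc12)c1ccc(O)cc1`, gives 20 ug/mL.

Of the two numbers, compound 1 stands highest, so it is the better tolerated of the two. The nearest to it is compound 3, which sits below it by a gap that lies beyond the usual scatter of repeated measurements. Compound 2 gives only (the limit of >= 20 ug/mL in this assay, at which 1 of the 3 values shown sits), so its place relative to the others cannot be fixed.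

The unmeasured compound 4, `O=C(COc1cccc2ccccc12)N/N=C/c1cccc(Cl)c1`, keeps the whole core of compound 1 and changes only the outer ring: 3-chlorophenyl in place of 4-chlorophenyl on a carbon with a double bond to nitrogen. The atoms are the same and only their arrangement on that ring differs. Within the data shown here, nothing among the measured compounds shows how the assay responds to moving the chlorine around the ring, and a change of this size is expected to give no step beyond the scatter. The step of no change at the digits printed from compound 1 to compound 4 (within the scatter) is therefore estimated to be essentially flat. Compound 4 is expected to give about 100 ug/mL, most likely between 40 ug/mL and 200 ug/mL.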

Compound 4, minimum cytotoxic concentration: 100 ug/mL
Estimate against measurement, compound 4: no gap at the digits printed, within the range that was stated.
By their numbers in this assay, from the lowest: compound 3; then compounds 1 and 4 (each within the scatter of the next).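

In this assay, among these compounds, the result gives no change at the digits printed from compound 1 to compound 4 (within the scatter) for 3-chlorophenyl in place of 4-chlorophenyl, the first step between two compounds that differ in one place. The earlier compounds shown here could not isolate any single change, but this pair shows that, with the rest of compound 1 kept, the two arrangements of the chlorine on this ring cannot be told apart in this assay. Nothing shown explains why the two compounds match.

This single pair leaves open whether the chlorine itself matters, which a plain phenyl ring with no chlorine on the same carbon would begin to show. It also leaves open whether the ring tolerates other changes in the same way, for example an amine or a carboxylic acid in place of the chlorine.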